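A few compounds are considered here, and "the series" means these few. Any claim that something is new, unique, unknown or untested is made for them only; others in the source may bear on it.

Measured compounds in a functional assay on KYSE-450 cells (Homo sapiens) for inhibition, read by MTT assay, with a stated time of 48 h; on this read-out higher numbers stand for weaker inhibition and lower numbers for stronger inhibition:
- compound 1, `C/C=C/C(=O)N(Cc1cccc(O)c1)c1cc(OC)c(OC)c(OC)c1`, gives 14700 nM
- compound 2, `COc1cc(NCc2cccc(O)c2)cc(OC)c1OC`, gives 71300 nM
- compound 3, `COc1ccc(CN(C(=O)CN=[N+]=[N-])c2cc(OC)c(OC)c(OC)c2)cc1O`, gives 160 nM

Compound 2 stands at the highest number of the three, meaning the weakest inhibition; the nearest is compound 1, which differs from it by a 4.9-fold higher number from compound 1 to compound 2 (0.69 log units; beyond the scatter), and compound 3 lies far lower.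

Compound 4, `COc1cc(NCc2ccc(Br)cc2)cc(OC)c1OC`, has not yet been measured. It differs from compound 2 in one place: 4-bromophenyl in place of 3-hydroxyphenyl on a saturated chain carbon bound to a nitrogen on an aromatic ring. For the measured compounds named here, the only measured step, a 4.9-fold higher number from compound 1 to compound 2 (0.69 log units; beyond the scatter), concerns a change on the nitrogen bound to the aromatic ring, not the group on the saturated chain carbon, so no measured step bears on this change. Going by the values given here, compound 3 carries a different pattern at that end, but no single-place step links it to compound 2 or compound 4. With nothing to anchor a direction, the expectation for compound 4 is a step of a 1.0-fold lower number from compound 2 to compound 4 (0.01 log units; within the scatter), that is, none beyond the scatter. Compound 4 is therefore estimated at 70000 nM, within a range from 20000 nM to 200000 nM.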

Compound 4, half-maximal inhibitory concentration: > 80000 nM
Compound 4: only a limit was reported (the forecaster's own chance of this, stated with the estimate: 25%); middle value at least 1.1-fold (0.05 log units) from the limit.
By their numbers in this assay, from the lowest: compound 3; then compound 1; then compound 2. At a limit, above all of these: compound 4.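

In this assay compound 4 gives > 80000 nM, which is a limit of the assay and not a number. For the compounds shown here, this gives the first reading at the saturated chain carbon, since the earlier single-place step concerned only the nitrogen: an at least 1.1-fold higher number from compound 2 to compound 4 (0.05 log units; that floor lies within the scatter). Replacing 3-hydroxyphenyl with 4-bromophenyl therefore shows no gain in inhibition, but the size of any loss stays unknown because the result is only a limit: the limit of > 80000 nM in this assay, at which 1 of the 4 values shown sits.

The compounds shown leave open whether the loss of the hydroxyl group or the arrival of the bromine matters more, which a plain phenyl ring at this place would help separate. They also leave open how a phenyl ring carrying an amine or a carboxylic acid would behave there.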